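Swapping an acrylate amide for a pyridinyl amine

This account rests on a few compounds, and the source may have more. Where it says the series, first, only, none or still open, it means among the compounds named here.

Measured compounds:
- compound 1 `CC(O)c1cccc(C(=O)N[C@@H](C)Cn2ccc(-c3ccc(C#N)c(Cl)c3)n2)c1`: 20100 nM
- compound 2 `CC(O)c1ccc(C(=O)N[C@@H](C)Cn2ccc(-c3ccc(C#N)c(Cl)c3)n2)cc1`: 9050 nM
- compound 3 `COC(=O)/C=C/C(=O)N[C@@H](C)Cn1ccc(-c2ccc(C#N)c(Cl)c2)n1`: "not determined" (no result reported)

Within the data shown here, in a functional assay on CWR22R cells (Homo sapiens) for antiproliferative activity, read by CCK-8 assay, with a stated time of 6 days (on this read-out lower numbers stand for stronger inhibition and higher numbers for weaker inhibition), compound 1 gives 20100 nM and compound 2 gives 9050 nM; the one measured step is a 2.2-fold lower number from compound 1 to compound 2 (0.35 log units; beyond the scatter). Compound 3 shares the same core but carries a (2-(methoxycarbonyl)ethenyl)carbonyl group on the amine nitrogen, and for it no number at all is available in this assay, so it stands nowhere on the scale set by compounds 1 and 2.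

Compound 4 `C[C@@H](Cn1ccc(-c2ccc(C#N)c(Cl)c2)n1)Nc1cccnc1` is the unmeasured analogue. The change from compound 3 is pyridin-3-yl in place of (2-(methoxycarbonyl)ethenyl)carbonyl on an amine nitrogen. Among the measured compounds shown here, neither compound 3 nor any step that touches the amine nitrogen has been measured, and the single recorded step, between compounds 1 and 2, concerns a different part of the molecule, so it does not bear on this change. Any expectation therefore rests only on the weak activity of the two measured analogues. Compound 4 is expected to give about 12000 nM in this assay, within a wide range from 2000 nM to 60000 nM.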

Compound 4, half-maximal inhibitory concentration: 21600 nM
Beside the measured number, compound 4's estimate is 1.8-fold (0.26 log units) below it, within the range that was stated.
By their numbers in this assay, from the lowest: compound 2; then compounds 1 and 4 (each within the scatter of the next).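

In this assay, among these compounds, compound 4 at 21600 nM yields no new step, as compound 3 has no number to set against it. The compounds shown leave open how pyridin-3-yl on the amine nitrogen compares with (2-(methoxycarbonyl)ethenyl)carbonyl there. Nothing available explains the value of compound 4.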